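The source may hold more compounds than are shown below. What is called first, only, known or untested is meant among the compounds shown, and "the series" means these compounds.

Compound 3 `Cc1nc(S(C)(=O)=O)ccc1Oc1ncnc(OC2CCN(C(=O)SC3CC3)CC2)c1F` was tested in a functional assay on isolated protein for inhibition of Glucose-dependent insulinotropic receptor (Homo sapiens), read by HTRF and cAMP accumulation (on this read-out higher numbers stand for an effect only at larger amounts of compound and lower numbers for an effect already at smaller amounts), where compound 3 gives 24.9 nM. Among the three measured compounds this is the second highest number: compound 2 `Cc1nc(S(C)(=O)=O)ccc1Oc1ncnc(OC2CCN(C(=O)O[C@H](C)C(F)(F)F)CC2)c1F` gives 9.2 nM, and compound 1 `Cc1nc(S(C)(=O)=O)ccc1Oc1ncnc(OC2CCN(C(=O)O[C@H](C)CF)CC2)c1F` gives 196 nM. The unmeasured compound 4 `CCc1cnc(C(=O)N2CCC(Oc3ncnc(Oc4ccc(S(C)(=O)=O)nc4C)c3F)CC2)nc1` differs from compound 3 in one place: a group of 8 heavy atoms (6 carbon, 2 nitrogen; one six-membered aromatic ring with 2 hetero atoms) in place of a group of 4 heavy atoms (3 carbon, 1 sulfur; one three-membered non-aromatic ring of carbon only), on a carbonyl carbon. Two measured steps alter the same carbonyl carbon. One exchange of groups there gave a 7.9-fold lower number from compound 1 to compound 3 (0.90 log units; beyond the scatter), and another gave a 2.7-fold higher number from compound 2 to compound 3 (0.43 log units; beyond the scatter); together these show that the group on the carbonyl carbon can move the number by a modest amount in either direction, though neither step brings in an aromatic ring. For the measured compounds named here, no measured pair shows the effect of the 5-ethylpyrimidin-2-yl group itself. A modest step in either direction, or none beyond the scatter, is therefore the expectation. Compound 4 is estimated at 30 nM, with a range from 8 nM to 120 nM. This estimate means an expected step of a 1.2-fold higher number from compound 3 to compound 4 (0.08 log units; within the scatter).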

Compound 4, half-maximal effective concentration: 4.7 nM
Estimate against measurement, compound 4: 6.4-fold (0.81 log units) above, and the stated range ends above it.
By their numbers in this assay, from the lowest: compounds 4 and 2 (each within the scatter of the next); then compound 3; then compound 1.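

In this assay, the carbonyl carbon accepts an aromatic ring attached directly through carbon, which none of the earlier groups offered: 5-ethylpyrimidin-2-yl gives a 5.3-fold lower number from compound 3 to compound 4 (0.72 log units; beyond the scatter) and a 42-fold lower number from compound 1 to compound 4 (1.62 log units; beyond the scatter). Set against the best earlier group, 1-(trifluoromethyl)ethoxy, it gives a 2.0-fold lower number from compound 2 to compound 4 (0.29 log units; within the scatter), so the two groups cannot be ranked, and a link through oxygen or sulfur is not needed for a low number at this position. Nothing here gives a measured reason for these differences. The compounds shown leave open how much of the result belongs to the ethyl group and how much to the ring itself, since no unsubstituted pyrimidin-2-yl or phenyl ring stands beside it. They also leave open how a methyl, a methoxy or a longer chain in place of the ethyl would read.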